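Trifluoromethyl in Place of tert-Butyl on an Aromatic Ring

The source may report more compounds than this note shows. Statements on the series, on what has been measured and on what is new or still open speak of the compounds shown alone.

Compound 1 `CCOC(=O)c1nn(-c2ccc(C(C)(C)C)cc2)c(=O)c2c(N)scc12` was tested in an assay on CHO-K1 cells for displacement of a labelled ligand from adenosine receptor A1 (Homo sapiens), tested at 50 uM (on this read-out lower numbers stand for less inhibition and higher numbers for more inhibition at the one concentration tested (going by the name of the read-out)), where compound 1 gives 23%. Compound 2 `CCOC(=O)c1nn(-c2cccc(C(F)(F)F)c2)c(=O)c2c(N)scc12`, which carries a trifluoromethyl on its aromatic ring, gives 32% in this assay. Compound 1 stands at the lower of these two numbers, yet the gap to compound 2 lies within the usual scatter of repeated measurements, so the two cannot be ranked. Compound 3 `CCOC(=O)c1nn(-c2ccc(C(F)(F)F)cc2)c(=O)c2c(N)scc12` has not yet been measured. It differs from compound 1 by trifluoromethyl in place of tert-butyl on an aromatic carbon. Since compound 2 gives 32% with a trifluoromethyl on its ring and compound 1 gives 23%, the expected step from compound 1 to compound 3 is a number 5 percentage points higher from compound 1 to compound 3 (within the scatter), a change with no direction beyond the scatter. Compound 3 is therefore estimated to give 28% in this assay, within a range of 14% to 42%.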

Compound 3, a percentage reported as inhibition, at one concentration (the size of the read-out at that concentration, not a potency): 77.2%
Beside the measured number, compound 3's estimate is 49.2 percentage points below it; measured number above the stated range.
By their numbers in this assay, from the lowest: compounds 1 and 2 (each within the scatter of the next); then compound 3.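

In this assay the change from tert-butyl to trifluoromethyl on this aromatic carbon is a large step, a number 54.2 percentage points higher from compound 1 to compound 3 (beyond the scatter) and so the group at this position matters greatly, even though the two groups have the same count of heavy atoms. Placement on the ring appears to matter as well: compound 2, with its trifluoromethyl on a different ring carbon, gives 32% in this assay while compound 3 gives 77.2% in the same test. The data shown offer no measured reason for the large step.

From the compounds shown here alone, whether a smaller group such as chlorine, or a group of another kind such as an amine or a carboxylic acid, would do as well at this carbon remains open. Also open, going by these compounds, is how compound 3 would behave across a range of concentrations, since this read-out comes from one concentration and is not a potency.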